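Changing the Aryl Group on an Aromatic Nitrogen

The source may hold more compounds than are shown below. What is called first, only, known or untested is meant among the compounds shown, and "the series" means these compounds.

In a functional assay on A549 cells (Homo sapiens) for antiproliferative activity, read by MTT assay, with a stated time of 72 h (a lower number here means a stronger inhibitor, a higher number a weaker inhibitor), compound 1 `CCCNC(=O)c1cc(Oc2ccc(NC(=O)c3nn(-c4ccc(C)cc4)c(=O)cc3C)cc2F)ccn1` gives 18000 nM, while compound 2 `CCCNC(=O)c1cc(Oc2ccc(NC(=O)c3nn(-c4ccccc4OC(F)(F)F)c(=O)cc3C)cc2F)ccn1` gives 4220 nM, the lower of the two numbers. Compound 3 `CCCNC(=O)c1cc(Oc2ccc(NC(=O)c3nn(-c4cccc(F)c4)c(=O)cc3C)cc2F)ccn1` carries 3-fluorophenyl in place of 2-(trifluoromethoxy)phenyl on an aromatic nitrogen. Among the compounds with values here, the only measured change at this place is a 4.3-fold lower number from compound 1 to compound 2 (0.63 log units; beyond the scatter), a modest step beyond the scatter. That single precedent gives a rough guide, so a modest rise in this assay is expected, though the direction remains uncertain. The expected change is a 1.9-fold higher number from compound 2 to compound 3 (0.28 log units; within the scatter). For compound 3 the estimated value is 8000 nM, with an expected range of 3000 nM to 20000 nM.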

Compound 3, half-maximal inhibitory concentration: 7020 nM
Beside the measured number, compound 3's estimate is 1.1-fold (0.06 log units) above it, within the range that was stated.
By their numbers in this assay, from the lowest: compounds 2 and 3 (each within the scatter of the next); then compound 1.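

In this assay, the change to the smaller 3-fluorophenyl gives a 1.7-fold higher number from compound 2 to compound 3 (0.22 log units; within the scatter), so compound 2 and compound 3 cannot be told apart. The step of a 2.6-fold lower number from compound 1 to compound 3 (0.41 log units; beyond the scatter) shows that a second fluorine-bearing aryl group also gives a lower number than 4-methylphenyl, so the earlier gain no longer rests on 2-(trifluoromethoxy)phenyl alone. No supporting data explain these results. Still open, from the compounds shown here alone, is how unsubstituted phenyl, a pyridine ring or a butyl chain on this nitrogen would compare.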